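Swapping an amine-bearing amide for a phenyl ester

A few compounds are considered here, and "the series" means these few. Any claim that something is new, unique, unknown or untested is made for them only; others in the source may bear on it.

Measured compounds:
compound 1 `CCn1c(C(=O)NCCN(C)C)ccc1C(CC)(CC)c1ccc(OCC(=O)C(C)(C)C)c(C)c1`: 2300 nM
compound 2 `CCn1c(C(=O)NCCN)ccc1C(CC)(CC)c1ccc(OCC(=O)C(C)(C)C)c(C)c1`: 180 nM
compound 3 `CCN(CC)CCCNC(=O)c1ccc(C(CC)(CC)c2ccc(OCC(O)C(C)(C)C)c(C)c2)n1CC`: 1100 nM

In a functional assay on HepG2 cells (Homo sapiens), read by MTT assay, with a stated time of 48 h (on this read-out higher numbers stand for weaker inhibition and lower numbers for stronger inhibition), compound 3 stands second highest of the three numbers; compound 2 gives 180 nM, and compound 1 gives 2300 nM. Compound 4 `CCn1c(C(=O)Oc2ccc(CCO)cc2)ccc1C(CC)(CC)c1ccc(OCC(O)C(C)(C)C)c(C)c1` has not been measured. It differs from compound 3 in one place: a group of 10 heavy atoms (8 carbon, 2 oxygen; one six-membered aromatic ring of carbon only) in place of a group of 9 heavy atoms (7 carbon, 2 nitrogen; no ring), on a carbonyl carbon.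

Among the compounds with values here, the only measured step, a 13-fold lower number from compound 1 to compound 2 (1.11 log units; beyond the scatter), concerns the end of the side chain on that same carbonyl carbon, where amino in place of dimethylamino gave a large change. This shows that the tail on the carbonyl carbon can move the number strongly, but it does not show what happens when the whole (3-(diethylamino)propyl)amino group leaves and an ester bearing an aromatic ring enters. Within the data shown here, with no direct precedent, the step is expected to be moderate and toward a higher number, with wide uncertainty: a 2.7-fold higher number from compound 3 to compound 4 (0.44 log units; beyond the scatter). Compound 4 is therefore estimated at 3000 nM, with a range from 700 nM to 13000 nM.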

Compound 4, half-maximal inhibitory concentration: > 50000 nM
Compound 4: only a limit was reported; the forecaster's own chance of this, stated with the estimate: 10%; middle value at least 16-fold (1.22 log units) away from the limit.
By their numbers in this assay, from the lowest: compound 2; then compound 3; then compound 1. At a limit, above all of these: compound 4.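

Putting the ester bearing an aromatic ring on the carbonyl carbon in place of the (3-(diethylamino)propyl)amino group gives, in this assay, an at least 45-fold higher number from compound 3 to compound 4 (1.65 log units; beyond the scatter). Compound 4 yields only a limit of the assay, not a number: the limit of > 50000 nM in this assay, at which 1 of the 4 values shown sits. The earlier compounds shown here showed a change at the end of the tail, a 13-fold lower number from compound 1 to compound 2 (1.11 log units; beyond the scatter), whereas this result shows that replacing the whole amine-bearing amide group can cost far more activity in this assay.

This single exchange changes the amide link, the amine and the aromatic ring together, so the compounds shown cannot say which of these matters. An ester carrying the 3-(diethylamino)propyl chain, or an amide carrying the same hydroxyethyl-substituted benzene ring, would separate these parts.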